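Adding a methyl to the acid side chain of compound 2

The source may report more compounds than this note shows. Statements on the series, on what has been measured and on what is new or still open speak of the compounds shown alone.

In an ADME assay on microsomes from liver (Mus musculus) for metabolic stability (a higher number here means faster removal of the compound, a lower number slower removal), compound 2 (`O=C(O)Cn1nc(Cn2cc3cc(OCC4CC4)c(Cl)cc3n2)c2ccccc2c1=O`) gives < 85 mL/min/kg which is a limit of the assay and not a number. In this assay compound 1 (`O=C(Cc1nn(CC(=O)N2CCOCC2)c(=O)c2ccccc12)Nc1ccc(OC(F)(F)F)c(Cl)c1`) gives 11900 mL/min/kg and compound 3 (`O=C(Cc1nn(C2CCNC2)c(=O)c2ccccc12)Nc1ccc(OC(F)(F)F)c(Cl)c1`) gives 16300 mL/min/kg as measured numbers. Both stand far over the limit of compound 2, the only one of the three at that limit (the limit of < 85 mL/min/kg in this assay, at which 1 of the 3 values shown sits).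

Compound 4 (`C[C@H](C(=O)O)n1nc(Cn2cc3cc(OCC4CC4)c(Cl)cc3n2)c2ccccc2c1=O`) differs from compound 2 by one change: methyl in place of hydrogen on a saturated chain carbon bound to an aromatic nitrogen and a carbonyl carbon so that carboxymethyl becomes 1-carboxyethyl, with methyl in place of hydrogen on a saturated chain carbon bound to an aromatic nitrogen and a carbonyl carbon.

For the measured compounds named here, no measured step starts from compound 2 or touches this chain carbon. The nearest one puts pyrrolidin-3-yl in place of ((morpholin-4-yl)carbonyl)methyl on an aromatic nitrogen and amounts to a 1.4-fold higher number from compound 1 to compound 3 (0.14 log units; within the scatter) although a whole group is exchanged. On that evidence no step beyond the scatter is expected in this assay and no direction is favoured. The expected move is a number no lower from compound 2 to compound 4 (the limit leaves the size open) and another limit instead of a number is quite possible. For compound 4 the estimated clearance is 85 mL/min/kg with an expected range of 45 mL/min/kg to 220 mL/min/kg if a number is reported.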

Compound 4, clearance: < 66.7 mL/min/kg
Compound 4 was reported as a limit; the forecaster's own chance of this, stated with the estimate: 60%; middle value at least 1.2-fold (0.10 log units) from the limit.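

In this assay compound 4 gives < 66.7 mL/min/kg as a limit of the assay and not a number. Compound 2 gives < 85 mL/min/kg as a limit too. For the compounds shown here, no step from compound 2 to compound 4 can be read from these two limits. The compounds shown leave open whether methyl in place of hydrogen on this chain carbon moves the clearance at all, and in which direction.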